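This account rests on a few compounds, and the source may have more. Where it says the series, first, only, none or still open, it means among the compounds named here.

In a functional assay on MCF7 cells (Homo sapiens) for inhibition (a lower number here means a stronger inhibitor, a higher number a weaker inhibitor), compound 1 `CC/C(=C(/c1ccc(/C=C/C(=O)O)cc1)c1cc2ccccc2[nH]1)c1ccccc1C#N` gives 9 nM. Compound 2 `CC/C(=C(/c1ccc(/C=C/C(=O)O)cc1)c1cc2ccccc2[nH]1)c1ccccc1OC(F)(F)F` gives 206 nM in this assay, and compound 3 `CC/C(=C(/c1ccc(/C=C/C(=O)O)cc1)c1cc2ccccc2[nH]1)c1ccc(C(F)(F)F)cc1` gives 139 nM. Compound 3 thus holds the second highest of the three numbers, close to compound 2 and far from compound 1. Compound 4 `CC/C(=C(/c1ccc(/C=C/C(=O)O)cc1)c1cc2ccccc2[nH]1)c1cccc(F)c1C#N` carries 2-cyano-3-fluorophenyl in place of 4-(trifluoromethyl)phenyl on a double-bonded chain carbon bound to a double-bonded chain carbon and a saturated chain carbon. The measured step of a 15-fold higher number from compound 1 to compound 3 (1.19 log units; beyond the scatter) runs this exchange in the reverse direction, and a 23-fold higher number from compound 1 to compound 2 (1.36 log units; beyond the scatter) shows the cyano group removed; both bear directly on the change. Going by the values given here, the added fluorine has no measured precedent. On this basis compound 4 is expected to return to the low end of this assay, near compound 1, a step of a 9.3-fold lower number from compound 3 to compound 4 (0.97 log units; beyond the scatter). Compound 4 is therefore estimated at 15 nM with a range of 5 nM to 50 nM.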

Compound 4, half-maximal inhibitory concentration: 40 nM
The estimate for compound 4 lay 2.7-fold (0.43 log units) below the measured number; low and high end bracket the measured number.
By their numbers in this assay, from the lowest: compound 1; then compound 4; then compounds 3 and 2 (each within the scatter of the next).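

In this assay, fluoro on the nitrile-bearing ring is not neutral: a 4.4-fold higher number from compound 1 to compound 4 (0.65 log units; beyond the scatter), the only change shown that keeps the nitrile. The 2-cyano-3-fluorophenyl group still gives lower numbers than 4-(trifluoromethyl)phenyl, a 3.5-fold lower number from compound 3 to compound 4 (0.54 log units; beyond the scatter), and 2-(trifluoromethoxy)phenyl, a 5.2-fold lower number from compound 2 to compound 4 (0.71 log units; beyond the scatter), so with fluoro present the nitrile-bearing group keeps part of its advantage at this position. No evidence at hand accounts for these differences.

On these data alone, whether the loss is particular to fluoro remains open; chloro or methyl in its place would test this.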